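Side-chain swap at the amino acid position: compound 3

The compounds below may be only part of what the source reports. "The series", "measured", "known", "first", "only" and "open" are said of these compounds alone.

Measured compounds:
compound 1 `N=C(N)NCCC[C@H](NC(=O)CN(c1nc(Cl)nc2[nH]cnc12)C1CC1)C(=O)O`: 10.3%
compound 2 `NCCCC[C@H](NC(=O)CN(c1nc(Cl)nc2[nH]cnc12)C1CC1)C(=O)O`: 9.79%

In a functional assay on the whole organism (Tail, strain ICR) with Mus musculus as the target, in the tail flick test, with a stated time of 120 min, at a dose of 12.5 umol/kg by the oral route (a higher number here means a stronger effect of the compound at the dose given, a lower number a weaker effect), compound 1 gives 10.3% and compound 2 gives 9.79%. Compound 2 is the lower of the two numbers, but only by a number 0.5 percentage points lower from compound 1 to compound 2 (within the scatter), so the two stand together within the scatter.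

Compound 3 `CC(C)C[C@H](NC(=O)CN(c1nc(Cl)nc2[nH]cnc12)C1CC1)C(=O)O` is not yet measured. Relative to compound 2 the change is isopropyl in place of 3-aminopropyl on a saturated chain carbon, two bonds along the chain from an amide-type nitrogen and a carbonyl carbon. Within the data shown here, the only measured step, a number 0.5 percentage points lower from compound 1 to compound 2 (within the scatter), sits on the same side chain, one bond further out, and shows that exchanging the terminal group there left the read-out essentially unchanged at a low level. That step bears on the present one only in part, as here the hydrogen-bond donor and acceptor of the chain are removed rather than exchanged. With both measured numbers low and close, no step beyond the scatter is expected in this assay. Compound 3 is therefore estimated at 9%, range 0% to 20%, a step of a number 0.8 percentage points lower from compound 2 to compound 3 (within the scatter).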

Compound 3, a percentage reported as activity, at one dose (the size of the read-out at that dose, not a potency): 13.3%
The estimate for compound 3 lay 4.3 percentage points below the measured number; low and high end bracket the measured number.
By their numbers in this assay, from the lowest: compounds 2, 1 and 3 (each within the scatter of the next).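

Isopropyl in place of 3-aminopropyl, on a saturated chain carbon two bonds along the chain from an amide-type nitrogen and a carbonyl carbon, gives a number 3.5 percentage points higher from compound 2 to compound 3 (within the scatter) in this assay, and the wider exchange gives a number 3 percentage points higher from compound 1 to compound 3 (within the scatter) in the same test. The earlier pair exchanged one nitrogen-bearing chain end for another, whereas these steps show that a side chain with no nitrogen at all also stays within the scatter of both nitrogen-bearing chains at this low level of effect. Nothing available accounts for these numbers.

From the compounds shown here alone, whether a carboxylic acid, a phenyl ring or a bare methyl group on this carbon would give a step beyond the scatter remains open. All three numbers also come from one dose and one time point, so any separation among these chains under other conditions is unknown.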